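Chloro to Methoxy on a Shared Core

The compounds below may be only part of what the source reports. "The series", "measured", "known", "first", "only" and "open" are said of these compounds alone.

Of the compounds shown here, three built on one shared core have been measured in an ADME assay for permeability, using PAMPA, at pH 7.4; a higher number here means that the compound crosses the layer faster, a lower number that the compound crosses the layer more slowly. Compound 1 `Cc1cc(NC(=O)Nc2ccc(C)c(Cl)c2)c2ccccc2n1` gives 262 10^-6 cm/s, compound 2 `Cc1cc(NC(=O)Nc2ccc(Cl)c(Cl)c2)c2ccccc2n1` gives 197 10^-6 cm/s, and compound 3 `Cc1cc(NC(=O)Nc2ccc(F)c(F)c2)c2ccccc2n1` gives 478 10^-6 cm/s. Compound 2 thus sits within the usual scatter of compound 1, while the number for compound 3 lies above it by more than that scatter.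

Compound 4 `COc1ccc(NC(=O)Nc2cc(C)nc3ccccc23)cc1Cl` has not yet been measured. It differs from compound 2 by a single change (methoxy in place of chloro on an aromatic carbon), which is methoxy in place of chloro on an aromatic carbon, para to a large group and ortho to a chloro group.

Among the compounds with values here, only one measured step touches that same carbon, and it is a 1.3-fold lower number from compound 1 to compound 2 (0.12 log units; within the scatter), with chloro in place of methyl. That step is small and stays within the scatter. Within the data shown here, compound 3 differs from compound 2 in more than one place, so it gives no clean comparison, and no measured compound carries a methoxy group. With so little to go on, no shift beyond the scatter is expected in this assay, only a wide margin of doubt. The expected step is a 1.2-fold higher number from compound 2 to compound 4 (0.07 log units; within the scatter). For compound 4 the estimated value is 230 10^-6 cm/s, with an expected range from 110 10^-6 cm/s to 470 10^-6 cm/s.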

Compound 4, apparent permeability: 336 10^-6 cm/s
Compound 4: middle estimate off by 1.5-fold (0.16 log units), on the low side, and the stated range covers the measured number.
By their numbers in this assay, from the lowest: compounds 2, 1, 4 and 3 (each within the scatter of the next, the first and the last beyond it).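

At this carbon, para to a large group and ortho to a chloro group, methoxy can now be set directly against two other groups in this assay: replacing chloro gives a 1.7-fold higher number from compound 2 to compound 4 (0.23 log units; within the scatter), and replacing methyl gives a 1.3-fold higher number from compound 1 to compound 4 (0.11 log units; within the scatter). Methoxy has more heavy atoms than chloro and carries a hydrogen-bond acceptor where chloro has none, yet both steps stay within the scatter, as does the earlier swap of methyl for chloro, a 1.3-fold lower number from compound 1 to compound 2 (0.12 log units; within the scatter), so the three groups tried at this carbon cannot be told apart in this read-out. Nothing available here explains why these steps are so small.

Still open, going by these compounds, is whether an amine, a carboxylic acid or a longer chain such as ethoxy on this same carbon would produce a step beyond the scatter. It is also unknown whether methoxy would give a similar result if the chloro group ortho to it were replaced by another group, such as fluoro.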